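The compounds below may be only part of what the source reports. "The series", "measured", "known", "first", "only" and "open" are said of these compounds alone.

Measured compounds:
Compound 1, `NCc1cnc([C@]23CC[C@@H](N(CCN4CCCC4)C(=O)Nc4ccc(F)c(C(F)(F)F)c4)CC2C3)s1`, gives 431 nM in a functional assay for antagonist activity at melanin-concentrating hormone receptor 1 (Homo sapiens); on this read-out higher numbers stand for weaker inhibition and lower numbers for stronger inhibition.
Compound 2, `NCc1ncc([C@]23CC[C@@H](N(CCN4CCCC4)C(=O)Nc4ccc(F)c(C(F)(F)F)c4)C2C3)s1`, gives 107 nM in this assay.

Of these two numbers, compound 2 holds the lower one; compound 1 gives a higher number, and the gap between them lies beyond the usual scatter of repeated measurements, so compound 2 shows the stronger inhibition of the pair. Compound 3, `C[C@@H]1CN(CCCN(C(=O)Nc2ccc(F)c(C(F)(F)F)c2)[C@@H]2CC[C@]3(c4cnc(CN)s4)CC23)[C@@H](C)CN1`, is the next structure and has not yet been measured. It differs from compound 2 in a single place: (2,5-dimethylpiperazin-1-yl)methyl in place of pyrrolidin-1-yl on a saturated chain carbon, two bonds along the chain from an amide-type nitrogen. For the measured compounds named here, no pair of measured compounds shows this same change, so there is no measured step to lean on, and the two values at hand tell nothing about it. The expectation is a small step from compound 2 to compound 3, a 1.4-fold higher number from compound 2 to compound 3 (0.15 log units; within the scatter), of a size that need not exceed the scatter. Compound 3 is therefore estimated at 150 nM, with a likely range from 50 nM to 500 nM.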

Compound 3, inhibition constant: 19 nM
The estimate for compound 3 lay 7.9-fold (0.90 log units) above the measured number; the whole stated range lies above it.
By their numbers in this assay, from the lowest: compound 3; then compound 2; then compound 1.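

At this position on the chain, in this assay, replacing pyrrolidin-1-yl with (2,5-dimethylpiperazin-1-yl)methyl gives a 5.6-fold lower number from compound 2 to compound 3 (0.75 log units; beyond the scatter) and so shows that this site can take a larger group and still respond strongly. Because this single step changes the chain, the ring and its substituents together, it cannot show which of these parts accounts for the gain. No measurement shown here gives a reason for the stronger inhibition.

From the compounds shown here alone, it remains open whether a 3-(pyrrolidin-1-yl)propyl group, with the longer chain but the original ring, would match compound 3. A piperazin-1-yl group without the two methyl groups, on the same chain, would likewise be needed to show whether those methyl groups and their defined stereocentres matter.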